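This account rests on a few compounds, and the source may have more. Where it says the series, first, only, none or still open, it means among the compounds named here.

Of the compounds shown here, three built on one shared core have been tested in a functional assay on IMR-32 cells (Homo sapiens) for cytotoxicity, read by sulforhodamine B assay, with a stated time of 48 h; on this read-out higher numbers stand for weaker inhibition and lower numbers for stronger inhibition. Compound 1 `CC1=C(/C=C/C(=O)/C=C/c2ccccc2)C(C)(C)CCC1` gives 20400 nM. Compound 2 `CC1=C(/C=C/C(=O)/C=C/c2ccc(Cl)cc2)C(C)(C)CCC1` gives 52300 nM, the highest of the three numbers, and compound 3 `CC1=C(/C=C/C(=O)/C=C/c2ccccc2Cl)C(C)(C)CCC1` gives 13700 nM. The steps of a 2.6-fold higher number from compound 1 to compound 2 (0.41 log units; beyond the scatter) and a 3.8-fold lower number from compound 2 to compound 3 (0.58 log units; beyond the scatter) are both modest, whereas a 1.5-fold lower number from compound 1 to compound 3 (0.17 log units; within the scatter) stays within the scatter. Compound 4 `CC1=C(/C=C/C(=O)/C=C/c2ccccc2C)C(C)(C)CCC1` is not yet measured; it differs from compound 2 in one place: 2-methylphenyl in place of 4-chlorophenyl on a double-bonded chain carbon bound to a double-bonded chain carbon. The step from compound 2 to compound 3 bears on this change most closely, since both exchange the 4-chlorophenyl for a differently substituted phenyl. Because a 3.8-fold lower number from compound 2 to compound 3 (0.58 log units; beyond the scatter) lowered the number beyond the scatter, a similar drop is expected, a 3.5-fold lower number from compound 2 to compound 4 (0.54 log units; beyond the scatter). Compound 4 is therefore estimated at 15000 nM, ranging from 6000 nM to 40000 nM.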

Compound 4, half-maximal inhibitory concentration: 63200 nM
The estimate for compound 4 lay 4.2-fold (0.62 log units) below the measured number; the whole stated range lies below it.
By their numbers in this assay, from the lowest: compounds 3 and 1 (each within the scatter of the next); then compounds 2 and 4 (each within the scatter of the next).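

Among the compounds shown here, the group's identity matters at this position, not just its location on the ring: methyl in place of chloro on an aromatic carbon gives a 4.6-fold higher number from compound 3 to compound 4 (0.66 log units; beyond the scatter) and so separates two groups that the earlier compounds could not compare. Chloro in place of hydrogen gives a 2.6-fold higher number from compound 1 to compound 2 (0.41 log units; beyond the scatter), and methyl in place of hydrogen gives a 3.1-fold higher number from compound 1 to compound 4 (0.49 log units; beyond the scatter) in the same direction, while 2-methylphenyl in place of 4-chlorophenyl gives only a 1.2-fold higher number from compound 2 to compound 4 (0.08 log units; within the scatter) and so shows no real difference. No measurement here explains why chloro and methyl part ways. Going by these compounds, whether a phenyl ring carrying an amine or a carboxylic acid on the shared core would give a lower number remains open.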